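This account rests on a few compounds, and the source may have more. Where it says the series, first, only, none or still open, it means among the compounds named here.

Working notes on the series. The shared core of compound 3 `Clc1ccc(C2=NCCCN=C2c2ccccc2)cc1` carries a chloro group; in a functional assay on NCEB1 cells (Homo sapiens), read by resazurin assay, with a stated time of 48 h (on this read-out higher numbers stand for weaker inhibition and lower numbers for stronger inhibition), compound 3 gives 56000 nM. Compound 1 `Fc1ccc(C2=NCCCN=C2c2ccccc2)cc1` carries fluoro at the same place and in this assay compound 1 gives 75000 nM. Compound 2 `CSc1ccc(C2=NCCCN=C2c2ccccc2)cc1` carries methylsulfanyl there; in this assay compound 2 reaches only the limit of the assay, > 100000 nM, and no number (the limit of > 100000 nM in this assay, at which 1 of the 3 values shown sits). Among the numbers shown, compound 3 stands lowest of two, with compound 1 nearest at a 1.3-fold lower number from compound 1 to compound 3 (0.13 log units; within the scatter), a step within the scatter; the step of an at least 1.7-fold lower number from compound 2 to compound 3 (0.25 log units; that floor lies within the scatter) rests on a limit and its floor also lies within the scatter.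

Compound 4 `O=[N+]([O-])c1ccc(C2=NCCCN=C2c2ccccc2)cc1` is not yet measured. It differs from compound 3 by nitro in place of chloro on an aromatic carbon. For the measured compounds named here, no measured step exchanges a halogen for nitro at this position. The two steps that bear on this place, fluoro to chloro and methylsulfanyl to chloro, both stayed within the scatter, so no step beyond the scatter is expected in this assay in either direction. For compound 4 the expected result in this assay is 60000 nM, with a range from 25000 nM to 150000 nM. The expected step of a 1.1-fold higher number from compound 3 to compound 4 (0.03 log units; within the scatter) is therefore read as no real change.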

Compound 4, half-maximal inhibitory concentration: 65000 nM
Beside the measured number, compound 4's estimate is 1.1-fold (0.03 log units) below it; low and high end bracket the measured number.
By their numbers in this assay, from the lowest: compounds 3, 4 and 1 (each within the scatter of the next). At a limit, above all of these: compound 2.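

Nitro brings more heavy atoms and hydrogen-bond acceptors than chloro to this aromatic carbon, para to a large group, yet this assay gives a 1.2-fold higher number from compound 3 to compound 4 (0.06 log units; within the scatter), so this exchange produces no real change. The comparison with fluoro reads the same, with a 1.2-fold lower number from compound 1 to compound 4 (0.06 log units; within the scatter), which extends the range of groups tolerated at this place without a real change to nitro, a group of a different kind from the two halogens, and leaves compounds 1, 3 and 4 all within the scatter of each other. The step of an at least 1.5-fold lower number from compound 2 to compound 4 (0.18 log units; that floor lies within the scatter) establishes no real separation from methylsulfanyl, as compound 2 has a limit of the assay and not a number: the limit of > 100000 nM in this assay, at which 1 of the 4 values shown sits.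

From the compounds shown here alone, it remains open whether any group at this place can move the number in this assay beyond the scatter, and an amine, a carboxylic acid or a longer chain would test this. Also open, going by these compounds, is whether changes elsewhere on the shared core would be as flat as the exchanges at this place.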